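The source may report more compounds than this note shows. Statements on the series, on what has been measured and on what is new or still open speak of the compounds shown alone.

Of the compounds shown here, two sharing the same bicyclic amine core have been measured in an assay on HEK293 cells for displacement of a labelled ligand from C-X-C chemokine receptor type 3 (Homo sapiens); on this read-out lower numbers stand for stronger inhibition and higher numbers for weaker inhibition. Compound 1 `CN(CC1=CC[C@H]2C[C@@H]1C2(C)C)Cc1cccc(I)c1` carries an iodo group on its benzyl ring and in this assay gives 7940 nM. Compound 2 `CN(CC1=CC[C@H]2C[C@@H]1C2(C)C)Cc1ccc(F)cc1` carries a fluoro group instead and gives 6310 nM. Of the two numbers, that of compound 2 is the lower, but the gap to compound 1 lies within the scatter of repeated measurements, so the two compounds cannot be told apart on this evidence.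

Compound 3 `CN(CC1=CC[C@H]2C[C@@H]1C2(C)C)Cc1ccc(-c2ccccc2F)cc1` is the next member, not yet measured in this assay. It differs from compound 2 in one place: 2-fluorophenyl in place of fluoro on an aromatic carbon, on an aromatic carbon of a six-membered aromatic ring of carbon only, para to a large group. For the measured compounds named here, no step of this kind has been measured within the set, so its effect cannot be read from the two compounds in hand. The step from compound 2 to compound 3 is expected to lower the number modestly, a 2.5-fold lower number from compound 2 to compound 3 (0.40 log units; beyond the scatter), though a result within the scatter would not be surprising. For compound 3 the estimate in this assay is 2500 nM, within a range from 500 nM to 12000 nM.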

Compound 3, inhibition constant: > 316 nM
Compound 3: a limit, no number; the forecaster's own chance of this, stated with the estimate: 10%; the middle value lies beyond the limit too.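

In this assay, for the compounds shown here, compound 3 gives > 316 nM, which is a limit and not a number, so no step from compound 2 to compound 3 can be read. The compounds shown leave open how large the effect of 2-fluorophenyl in place of fluoro is on this read-out, and in which direction it runs.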